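Acylguanidine exchanger inhibitors: pyrrolidinyl in place of tert-butoxy

The source may hold more compounds than are shown below. What is called first, only, known or untested is meant among the compounds shown, and "the series" means these compounds.

Measured so far:
compound 1 `CCSc1cc(C)c(C(=O)N=C(N)N)cc1S(C)(=O)=O`: 5.9 nM
compound 2 `Cc1cc(OC(C)(C)C)c(S(C)(=O)=O)cc1C(=O)N=C(N)N`: 9.4 nM

In a functional assay for inhibition of sodium/hydrogen exchanger (Oryctolagus cuniculus) (on this read-out lower numbers stand for stronger inhibition and higher numbers for weaker inhibition), compound 2 and compound 1 cannot be separated, as a 1.6-fold higher number from compound 1 to compound 2 (0.20 log units; within the scatter) lies within the scatter. Compound 3 `Cc1cc(N2CCCC2)c(S(C)(=O)=O)cc1C(=O)N=C(N)N` carries pyrrolidin-1-yl in place of tert-butoxy on an aromatic carbon. Within the data shown here, the only measured step on that aromatic carbon, a 1.6-fold higher number from compound 1 to compound 2 (0.20 log units; within the scatter), swapped ethylsulfanyl for tert-butoxy with no effect beyond the scatter; nothing measured covers a nitrogen-linked ring there, so the expectation rests on that single step. Expected for compound 3 is a step of a 1.0-fold lower number from compound 2 to compound 3 (0.02 log units; within the scatter), giving an estimate of 9 nM with a range from 3 nM to 27 nM.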

Compound 3, half-maximal inhibitory concentration: 11 nM
Estimate against measurement, compound 3: 1.2-fold (0.09 log units) below, within the range that was stated.
By their numbers in this assay, from the lowest: compounds 1, 2 and 3 (each within the scatter of the next).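

In this assay, a pyrrolidin-1-yl ring on this aromatic carbon, ortho to the methylsulfonyl group, reads the same as the open-chain groups: a 1.2-fold higher number from compound 2 to compound 3 (0.07 log units; within the scatter) and a 1.9-fold higher number from compound 1 to compound 3 (0.27 log units; within the scatter) both stay within the scatter. Ethylsulfanyl, tert-butoxy and pyrrolidin-1-yl therefore cannot be separated here, whether the group is linked through sulfur, oxygen or nitrogen, and with or without a ring. Nothing available speaks to the reason for this. On these data alone, whether a carboxylic acid, a primary amine or a piperidin-1-yl ring on this carbon would shift the number remains open.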